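The source may hold more compounds than are shown below. What is called first, only, known or untested is meant among the compounds shown, and "the series" means these compounds.

Measured in an ADME assay on microsomes from liver (Rattus norvegicus) for metabolic stability (a lower number here means that the compound disappears faster, a higher number that the compound lasts longer), each entry a limit and not a number:
- compound 1 `N#Cc1ccc(NCCNc2ncc(-c3ncc[nH]3)c(-c3ccc(Cl)cc3Cl)n2)nc1` gives > 0.5 h
- compound 2 `Nc1nc(NCCNc2ncc(-c3ncc[nH]3)c(-c3ccc(Cl)cc3)n2)ccc1[N+](=O)[O-]` gives > 0.5 h
- compound 3 `Nc1nc(NCCNc2ncc(-c3ncc[nH]3)c(-c3cc(F)ccc3F)n2)ccc1[N+](=O)[O-]` gives > 0.5 h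

Compound 3 therefore has no exact position in the series. Its value of > 0.5 h is a limit.

Compound 4 `Nc1nc(NCCNc2ncc(-c3ncc[nH]3)c(-c3ccc(F)cc3C(F)(F)F)n2)ccc1[N+](=O)[O-]` carries 4-fluoro-2-(trifluoromethyl)phenyl in place of 2,5-difluorophenyl, on an aromatic carbon ortho to a 1H-imidazol-2-yl group: 4-fluoro-2-(trifluoromethyl)phenyl in place of 2,5-difluorophenyl on an aromatic carbon.

Going by the values given here, the only measured step at this aromatic carbon is a step that the two limits leave unreadable from compound 2 to compound 3, so it gives no size to carry over. The evidence is the limit of > 0.5 h in this assay, at which 3 of the 3 values shown sit. No step beyond the scatter is expected, and the estimate is a step that the limit leaves unreadable from compound 3 to compound 4.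

The half-life expected for compound 4 is 0.8 h, in an estimated range from 0.4 h to 2 h.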

Compound 4, half-life: > 0.5 h
Compound 4 was reported as a limit (the forecaster's own chance of this, stated with the estimate: 80%); the middle value does not contradict the limit.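

In this assay compound 4 gives > 0.5 h, a limit, so its steps from compound 2 and compound 3 cannot be read. The compounds shown leave open the actual half-lives and whether the group on this aromatic carbon alters them.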